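A few compounds are considered here, and "the series" means these few. Any claim that something is new, unique, unknown or untested is made for them only; others in the source may bear on it.

Compound 1 `Cc1ccccc1C(=O)Nc1ncc(-c2ccccc2)n1C` gives > 100000 nM in a toxicity assay on THP-1 cells (Homo sapiens) for inhibition (on this read-out lower numbers stand for higher toxicity in this test and higher numbers for lower toxicity in this test), which is a limit of the assay and not a number. Compound 2 `Cn1c(-c2ccccc2)cnc1NC(=O)c1ccccc1` gives > 100000 nM in this assay, likewise a limit. Among the compounds with values here, the series so far therefore stands at the limit of > 100000 nM in this assay, at which 2 of the 2 values shown sit, and compound 2 has no number of its own.

Compound 3 `Cn1c(-c2ccccc2)cnc1NC(=O)c1ccc(Cl)cc1` differs from compound 2 by chloro in place of hydrogen on an aromatic carbon, or phenyl to 4-chlorophenyl. Within the data shown here, the only measured step, a step that the two limits leave unreadable from compound 1 to compound 2, is also a change on an aromatic carbon, but its size cannot be read, so it gives no measure for this change. No step beyond the scatter is expected, in either direction, and another limit is the likeliest report. The expected step is a number no higher from compound 2 to compound 3 (the limit leaves the size open). For compound 3 the estimated value is 100000 nM, with an expected range from 40000 nM to 200000 nM.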

Compound 3, half-maximal cytotoxic concentration: > 100000 nM
Compound 3 ended at the assay's limit; the forecaster's own chance of this, stated with the estimate: 80%; the middle value sits exactly at the limit.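

Within the data shown here, compound 1, compound 2 and compound 3 all report a limit and not a number in this assay, so no step among them can be read: the limit of > 100000 nM in this assay, at which 3 of the 3 values shown sit. The compounds shown leave open whether chloro in place of hydrogen on an aromatic carbon changes this read-out at all.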